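Phenoxy in Place of an Ester-Bearing Phenyl Ring

The source may report more compounds than this note shows. Statements on the series, on what has been measured and on what is new or still open speak of the compounds shown alone.

Measured compounds:
- compound 1, `COC(=O)c1cccc(-c2ccc([C@H]3S[C@@H](C)C(=O)Nc4c3c(C)nn4-c3ccccc3C)cc2)c1`: "not active" (no number reported) in an assay on isolated protein for agonist activity at Bile acid receptor (Homo sapiens), read by AlphaScreen, with a stated time of 30 min; on this read-out lower numbers stand for an effect already at smaller amounts and higher numbers for an effect only at larger amounts of compound
- compound 2, `Cc1nn(-c2ccccc2F)c2c1C(c1ccc(Oc3ccccc3)cc1)SC(C)C(=O)N2`: 3900 nM in this assay

Compound 1 has no single number in this assay; it is recorded as "not active" (no number reported) without a value, so it cannot be placed on the scale beside compound 2. Compound 3, `Cc1ccccc1-n1nc(C)c2c1NC(=O)[C@H](C)S[C@@H]2c1ccc(Oc2ccccc2)cc1`, has not yet been measured. It differs from compound 1 in one place: phenoxy in place of 3-(methoxycarbonyl)phenyl on an aromatic carbon. Going by the values given here, no step between two measured compounds shows what this change does. On these data alone, compound 2, which also carries a phenoxy group, gives 3900 nM in this assay, which suggests that the change from compound 1 to compound 3 could move the read-out from no effect toward a measurable one, though by how much remains open. Compound 3 is therefore expected to give about 4000 nM, within a range of 1000 nM to 15000 nM.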

Compound 3, half-maximal effective concentration: 1300 nM
Compound 3: the middle estimate sits 3.1-fold (0.49 log units) above what was measured; low and high end bracket the measured number.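

No new step can be read from compound 1 to compound 3: in this assay compound 1 is recorded as "not active" (no number reported) without a number, while compound 3 gives 1300 nM as a number. The compounds shown leave open how large the effect of phenoxy in place of 3-(methoxycarbonyl)phenyl is. Nothing given here explains the result.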